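The source may report more compounds than this note shows. Statements on the series, on what has been measured and on what is new or still open speak of the compounds shown alone.

Measured compounds and their values:

compound 1 `CC1(COc2cccc(-c3ccc(F)nc3)n2)CCn2cc([N+](=O)[O-])nc2O1`: > 64000 nM
compound 2 `CC1(COc2cccc(-c3ccc(F)cc3)n2)CCn2cc([N+](=O)[O-])nc2O1`: > 64000 nM
compound 3 `O=[N+]([O-])c1cn2c(n1)OC(COc1ncc(-c3ccc(F)cc3)cn1)CC2`: > 64000 nM

All three were run in an ADME assay on MRC5 cells (Homo sapiens) for cytotoxicity, read by resazurin assay, with a stated time of 72 h; a higher number here means a weaker inhibitor, a lower number a stronger inhibitor. Compound 1 gives > 64000 nM there, which is a limit of the assay and not a number. Compound 2 gives > 64000 nM, again a limit. Compound 3 gives > 64000 nM, also a limit. The change from compound 2 to compound 1 is 6-fluoropyridin-3-yl in place of 4-fluorophenyl on an aromatic carbon, and the step it made, a step that the two limits leave unreadable from compound 2 to compound 1, cannot be read because of the limit of > 64000 nM in this assay, at which 3 of the 3 values shown sit. The difference between the cores of compound 2 and compound 3 is not broken down here.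

Compound 4 `O=[N+]([O-])c1cn2c(n1)OC(COc1ncc(-c3ccc(F)nc3)cn1)CC2` has not yet been measured. It differs from compound 3 by 6-fluoropyridin-3-yl in place of 4-fluorophenyl on an aromatic carbon. Among the compounds with values here, this is the same kind of change as the one from compound 2 to compound 1, but the surroundings differ: in compound 1 the entering group sits on an aromatic carbon of a six-membered aromatic ring with 1 nitrogen, next to the ring nitrogen, meta to a large group, whereas in compound 4 it sits on an aromatic carbon of a six-membered aromatic ring with 2 nitrogen, two atoms from the ring nitrogen, para to a large group.

Since the measured step gives no readable size, the expectation for compound 4 rests on compound 3 and its value > 64000 nM together with the limit of > 64000 nM in this assay, at which 3 of the 3 values shown sit. The step from compound 3 to compound 4 is expected to be a number no higher from compound 3 to compound 4 (the limit leaves the size open). Compound 4 is therefore expected to give about 64000 nM in this assay, most likely reported as a limit, with a range from 32000 nM to 200000 nM.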

Compound 4, half-maximal inhibitory concentration: > 64000 nM
Compound 4: a limit, no number; the forecaster's own chance of this, stated with the estimate: 85%; the middle value lies on the limit itself.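

No step can be read between compound 3 and compound 4, since the values of both are limits of the assay and not numbers: the limit of > 64000 nM in this assay, at which 4 of the 4 values shown sit.

The compounds shown leave open what the true values of all four compounds are in this assay, and so whether 6-fluoropyridin-3-yl in place of 4-fluorophenyl changes the result at all.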